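Chlorophenyl swap from compound 1 to compound 4

The source may hold more compounds than are shown below. What is called first, only, known or untested is meant among the compounds shown, and "the series" means these compounds.

Measured so far in a functional assay on MCF7 cells (Homo sapiens) for antiproliferative activity, read by MTT assay, with a stated time of 48 h; a lower number here means a stronger inhibitor, a higher number a weaker inhibitor:
- compound 1 `COc1cc(-c2cccc3nc(-c4cccc(F)c4)oc23)cc(OC)c1OC`: > 25000 nM (a limit)
- compound 2 `COc1cc(-c2cccc3nc(-c4ccc(F)cc4)oc23)cc(OC)c1OC`: > 25000 nM (a limit)
- compound 3 `COc1cc(-c2cccc3nc(-c4cccc(Cl)c4)oc23)cc(OC)c1OC`: > 25000 nM (a limit)

Compound 1 stands at a limit of the assay and not at a number. For the measured compounds named here, the series so far rests entirely on (the limit of > 25000 nM in this assay, at which 3 of the 3 values shown sit).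

In compound 4 `COc1cc(-c2cccc3nc(-c4ccc(Cl)cc4)oc23)cc(OC)c1OC`, 4-chlorophenyl stands in place of 3-fluorophenyl on an aromatic carbon of the shared core (4-chlorophenyl in place of 3-fluorophenyl on an aromatic carbon).

Going by the values given here, three measured steps bear on this change: a step that the two limits leave unreadable from compound 1 to compound 2, a step that the two limits leave unreadable from compound 1 to compound 3 and a step that the two limits leave unreadable from compound 2 to compound 3. Between them they cover both parts of the change, 4-fluorophenyl in place of 3-fluorophenyl and chloro in place of fluoro, yet none has a readable size. They therefore give no measured direction, and no step beyond the usual scatter is expected in this assay.

The expectation rests on compound 2, a limit at > 25000 nM. It also rests on compound 3, a limit at > 25000 nM.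

The expected step is a step that the limit leaves unreadable from compound 1 to compound 4, with no direction to be read from the data. Compound 4 is expected to be reported as a limit again. The estimate for compound 4 is 30000 nM, with an expected range from 15000 nM to 60000 nM.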

Compound 4, half-maximal inhibitory concentration: > 25000 nM
Compound 4: a limit, no number (the forecaster's own chance of this, stated with the estimate: 85%); the middle value does not contradict the limit.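

In this assay compound 4 gives > 25000 nM as a limit and not a number. No new step can be read among compound 1, compound 2, compound 3 and compound 4. The compounds shown leave open whether any phenyl substitution on the shared core gives a measurable value. The series still rests on one limit: the limit of > 25000 nM in this assay, at which 4 of the 4 values shown sit.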